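This account rests on a few compounds, and the source may have more. Where it says the series, first, only, none or still open, it means among the compounds named here.

Measured compounds in a functional assay on Ehrlich cells (Mus musculus) for cytotoxicity, read by trypan blue exclusion, with a stated time of 2 h, tested at 50 ug/mL; on this read-out higher numbers stand for a stronger effect at the one concentration tested and lower numbers for a weaker effect:
- compound 1, `N#CC1=C(NC(=S)Nc2ccc(Cl)cc2)N(c2ccc(S(N)(=O)=O)cc2)C2=C(C(=O)CCC2)C1c1ccc(Cl)cc1Cl`: 100%
- compound 2, `N#CC1=C(NC(N)=O)N(c2ccc(S(N)(=O)=O)cc2)C2=C(C(=O)CCC2)C1c1ccc(Cl)cc1Cl`: 40%
- compound 3, `N#CC1=C(N2C(=O)CCC2=O)N(c2ccc(S(N)(=O)=O)cc2)C2=C(C(=O)CCC2)C1c1ccc(Cl)cc1Cl`: 70%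

Compound 3 stands second highest of the three numbers; its nearest neighbour is compound 1, higher by a number 30 percentage points lower from compound 1 to compound 3 (beyond the scatter), and the furthest is compound 2, below it by a number 30 percentage points higher from compound 2 to compound 3 (beyond the scatter).

Compound 4, `N#CC1=C(NS(=O)(=O)c2ccc(Br)cc2)N(c2ccc(S(N)(=O)=O)cc2)C2=C(C(=O)CCC2)C1c1ccc(Cl)cc1Cl`, has not been measured. Its change from compound 3 is ((4-bromophenyl)sulfonyl)amino in place of 2,5-dioxopyrrolidin-1-yl on a double-bonded ring carbon.

Among the compounds with values here, the step that bears on this is the one from compound 1 to compound 3, where a group with one six-membered aromatic ring of carbon only gave way to the 2,5-dioxopyrrolidin-1-yl group, and the activity fell by a number 30 percentage points lower from compound 1 to compound 3 (beyond the scatter). The present change goes the other way, bringing back a group of 11 heavy atoms with one six-membered aromatic ring of carbon only on the same double-bonded ring carbon. The step from compound 1 to compound 2, a number 60 percentage points lower from compound 1 to compound 2 (beyond the scatter), also went with loss of an aromatic ring. A modest rise is therefore expected, a number 20 percentage points higher from compound 3 to compound 4 (beyond the scatter), with the estimate for compound 4 at 90%, between 70% and 100%.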

Compound 4, a percentage reported as activity, at one concentration (the size of the read-out at that concentration, not a potency): 90%
For compound 4 middle estimate and measured number coincide at the digits printed, within the range that was stated.
By their numbers in this assay, from the lowest: compound 2; then compound 3; then compounds 4 and 1 (each within the scatter of the next).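

At the double-bonded ring carbon next to the ring nitrogen, ((4-bromophenyl)sulfonyl)amino gives a clear gain over both non-aryl groups in this assay (a number 20 percentage points higher from compound 3 to compound 4 (beyond the scatter); a number 50 percentage points higher from compound 2 to compound 4 (beyond the scatter)). On the amine nitrogen, the read-out does not separate the (4-bromophenyl)sulfonyl group from the group of compound 1 (a number 10 percentage points lower from compound 1 to compound 4 (within the scatter)), so the high read-out seen with compound 1 is not confined to that one group, and two different groups that each carry a six-membered aromatic ring of carbon only stand level here. No measurement shown explains these steps.

Still open, as far as these compounds go, is whether the aromatic ring, the sulfonyl link or the bromine accounts for the gain; a plain phenylsulfonyl group and a methylsulfonyl group on the same amine nitrogen would separate these. From the compounds shown here alone, with one concentration per compound, potency also remains open.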